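Propyl Gives Way to 2-Chlorophenyl: What to Expect

The compounds below may be only part of what the source reports. "The series", "measured", "known", "first", "only" and "open" are said of these compounds alone.

Compound 1 `CCCCn1cc(COc2cc(O)c3c(c2)O[C@H](c2ccc(OC)c(O)c2)C/C3=N\O)nn1` was tested in a functional assay on RAW264.7 cells (Mus musculus) for inhibition, read by Griess assay, with stated times of 2 h and 24 h (on this read-out higher numbers stand for weaker inhibition and lower numbers for stronger inhibition), where compound 1 gives 8900 nM. Its only companion with a measured number is compound 2 `COc1ccc([C@@H]2CC(=O)c3c(O)cc(OCc4cn(CC5CC5)nn4)cc3O2)cc1O`; in this assay compound 2 gives 11900 nM. These two values lie within the usual scatter of each other, so neither compound can be called the stronger inhibitor; compound 1 simply carries the lower of the two numbers.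

Compound 3 `COc1ccc([C@@H]2C/C(=N\O)c3c(O)cc(OCc4cn(Cc5ccccc5Cl)nn4)cc3O2)cc1O` has not yet been measured. It differs from compound 1 in one place: 2-chlorophenyl in place of propyl on a saturated chain carbon bound to an aromatic nitrogen. Within the data shown here, no measured pair in this small set shows that exchange, so the size of the step has no precedent here and must be judged from the structural change alone. The expected step in this assay is a 1.5-fold lower number from compound 1 to compound 3 (0.17 log units; within the scatter), a modest shift toward lower numbers, if any, and one that may well fall inside the scatter. For compound 3 the estimated value in this assay is 6000 nM, with an expected range from 2000 nM to 20000 nM.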

Compound 3, half-maximal inhibitory concentration: 13400 nM
For compound 3 the middle estimate is 2.2-fold (0.35 log units) below the measured one; the range from low to high includes it.
By their numbers in this assay, from the lowest: compounds 1, 2 and 3 (each within the scatter of the next).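

In this assay, among these compounds, putting 2-chlorophenyl in place of propyl on a saturated chain carbon bound to an aromatic nitrogen gives a 1.5-fold higher number from compound 1 to compound 3 (0.18 log units; within the scatter), the first reading of any change at this position. The same difference, cut one bond further out, reads butyl to 2-chlorobenzyl, so an open chain and a chlorine-bearing six-membered aromatic ring, 7 heavy atoms in place of 3, cannot be told apart here: compound 1 gives 8900 nM and compound 3 gives 13400 nM. Nothing available accounts for this outcome, and the pair alone offers no explanation for it.

As far as these compounds go, it remains open whether any group at this place can move the number beyond the scatter, for instance a plain benzyl, a longer chain, an amine or a carboxylic acid. One pair also cannot show whether the exchange from propyl to 2-chlorophenyl would read the same on the core of compound 2, or whether a change elsewhere on the core of compound 1 would matter more than this one.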